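The source may hold more compounds than are shown below. What is called first, only, known or untested is meant among the compounds shown, and "the series" means these compounds.

Working notes, series read in a functional assay on EBC-1 cells (Homo sapiens) for antiproliferative activity, with a stated time of 72 h; on this read-out lower numbers stand for stronger inhibition and higher numbers for weaker inhibition:

- compound 1 `Cn1cc(-c2cn3c(Cc4ccc5ncccc5c4)cnc3cc2C(F)(F)F)cn1`: "not determined" (no result reported)
- compound 2 `N#Cc1ccc(-c2cc(F)c3ncc(Cc4ccc5ncccc5c4)n3c2)cn1`: 189 nM
- compound 3 `CN1CCN(C(=O)c2ccc(-c3cc(F)c4ncc(Cc5ccc6ncccc6c5)n4c3)cc2F)CC1`: 869 nM

Compound 3 carries the higher of the two numbers available in this assay, at 869 nM. The nearest is compound 2 at 189 nM, a lower number by more than the scatter. Compound 1 adds no number. Among the compounds with values here, no two measured compounds differ in one place only, so the data hold no direct step to read across, and the gap between compound 2 and compound 3 cannot be assigned to any single structural difference.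

The next entry is compound 4 `O=C(NC1CCOCC1)c1ccc(-c2cc(F)c3ncc(Cc4ccc5ncccc5c4)n3c2)cc1F`, still unmeasured. It is compound 3 with one change on a carbonyl carbon: (oxan-4-yl)amino in place of 4-methylpiperazin-1-yl on a carbonyl carbon. In words, (oxan-4-yl)amino stands in place of 4-methylpiperazin-1-yl, and the rest of the structure stays the same.

Within the data shown here, with no measured precedent for this swap, no step beyond the scatter is expected in this assay. A lean towards a lower number is all that can be argued, and it rests only on compound 2 at 189 nM lying under compound 3. The expected change is a 1.9-fold lower number from compound 3 to compound 4 (0.29 log units; within the scatter). For compound 4 the estimated value is 450 nM, with an expected range of 130 nM to 1500 nM.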

Compound 4, half-maximal inhibitory concentration: 70.5 nM
Beside the measured number, compound 4's estimate is 6.4-fold (0.81 log units) above it; measured number outside the range, below it.
By their numbers in this assay, from the lowest: compound 4; then compound 2; then compound 3.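

In this assay, within the data shown here, the group on the carbonyl carbon now proves to matter: with (oxan-4-yl)amino in place of 4-methylpiperazin-1-yl, a 12-fold lower number from compound 3 to compound 4 (1.09 log units; beyond the scatter), the first step that can be assigned to a single change, and one well beyond the scatter. The two groups match in heavy atoms and in hydrogen-bond acceptors, but only (oxan-4-yl)amino carries a hydrogen-bond donor, and it has an oxygen where 4-methylpiperazin-1-yl has a second nitrogen. No measurement shown ties the step to either of these differences.

Still open, going by these compounds, is which difference goes with the step: morpholin-4-yl on the same carbonyl carbon would keep the oxygen without the amide hydrogen, while (1-methylpiperidin-4-yl)amino would keep the amide hydrogen with a nitrogen in the ring. Among these compounds, compound 2 differs from compound 3 and compound 4 in more than one place, so no step to it can be read, and whether this swap would hold on a different core also remains open.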